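Acetyl Indoles: From Fluoro to Methoxy on the Aryl Ring

The source may hold more compounds than are shown below. What is called first, only, known or untested is meant among the compounds shown, and "the series" means these compounds.

Measured so far:
Compound 1 `COc1ccc(-c2cc(C(C)=O)c3[nH]c(-c4ccccc4)cc3c2)cc1` — 87.9%
Compound 2 `COc1ccc(-c2cc3cc(-c4ccccc4)cc(C(C)=O)c3[nH]2)cc1` — 80.5%
Compound 3 `COc1ccc(-c2cc3cc(-c4ccc(F)cc4)cc(C(C)=O)c3[nH]2)cc1` — 81%

The three measured compounds were each tested in a functional assay on HeLa cells (Homo sapiens) for cytotoxicity, read by MTT assay, with a stated time of 2 days, tested at 0.1 uM (a higher number here means a weaker effect of the compound at the concentration tested, a lower number a stronger effect), and all three give high numbers, meaning only weak effects at this concentration. Compound 3 stands second highest of the three; its nearest neighbour is compound 2, whose number lies a number 0.5 percentage points higher from compound 2 to compound 3 (within the scatter), and its furthest is compound 1, which sits higher, yet both gaps are within the scatter. Going by the values given here, the only single step measured, a number 0.5 percentage points higher from compound 2 to compound 3 (within the scatter), puts fluoro in place of hydrogen and does not move the number beyond the scatter.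

Compound 4 `COc1ccc(-c2cc(C(C)=O)c3[nH]c(-c4ccc(OC)cc4)cc3c2)cc1` is not yet measured. It differs from compound 3 as follows: methoxy in place of fluoro on an aromatic carbon. The fluoro leaves and a methoxy enters on the same aromatic carbon, so that the 4-fluorophenyl becomes a 4-methoxyphenyl.

Among the compounds with values here, no measured step concerns a methoxy on this ring, so the bearing is indirect: the one change made at this position, a number 0.5 percentage points higher from compound 2 to compound 3 (within the scatter), was flat, and no measured compound departs from the narrow band the three occupy. Compound 4 is therefore expected to show no step beyond the scatter, a number 1 percentage points higher from compound 3 to compound 4 (within the scatter). The estimate for compound 4 in this assay is 82%, expected to lie between 70% and 93%.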

Compound 4, a percentage reported as activity, at one concentration (the size of the read-out at that concentration, not a potency): 74.5%
For compound 4 the middle estimate is 7.5 percentage points above the measured one, and the stated range covers the measured number.
By their numbers in this assay, from the lowest: compounds 4, 2, 3 and 1 (each within the scatter of the next, the first and the last beyond it).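

In this assay the methoxy on this ring gives the first step beyond the scatter among the compounds shown, a number 13.4 percentage points lower from compound 1 to compound 4 (beyond the scatter), which means a modestly stronger effect when the 4-methoxyphenyl takes the place of the plain phenyl. The other two comparisons stay inside the scatter: a number 6.5 percentage points lower from compound 3 to compound 4 (within the scatter) for methoxy in place of fluoro, and a number 6 percentage points lower from compound 2 to compound 4 (within the scatter) for methoxy in place of hydrogen, so the change reads as real only against compound 1 and this position cannot be called sensitive on that one step alone. Nothing available accounts for why the step clears the scatter in one comparison and not in the other two.

The compounds shown leave open whether other groups on this aromatic carbon, such as an amine, a carboxylic acid or a longer chain like butoxy, would move the number further, or whether the step is particular to methoxy. this assay gives the size of the read-out at one concentration only, so the four can be compared only by a stronger or weaker effect at that concentration.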